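The source may hold more compounds than are shown below. What is called first, only, known or untested is meant among the compounds shown, and "the series" means these compounds.

Within the data shown here, compound 1 `Nc1nc(-c2ccccc2)nc2cn(Cc3ccccc3)nc12` is one of two compounds measured in an assay on CHO cells for displacement of a labelled ligand from adenosine receptor A3 (Homo sapiens), read by scintillation counting, with a stated time of 60 min (on this read-out higher numbers stand for weaker inhibition and lower numbers for stronger inhibition), where compound 1 gives 54 nM. That is the higher of the two numbers: compound 2 `Nc1nc(-c2cccs2)nc2cn(-c3ccccc3)nc12` gives 9.7 nM in this assay, and the gap between the two lies beyond the scatter. Compound 3 `O=C(Nc1nc(-c2ccccc2)nc2cn(Cc3ccccc3)nc12)c1ccccc1` is not yet measured. It differs from compound 1 by benzoyl in place of hydrogen on a nitrogen on an aromatic ring. With no measured step of this kind in the series, the direction rests on the change alone; a modest step to a lower number, near the edge of the scatter, is expected for compound 3, as a 1.8-fold lower number from compound 1 to compound 3 (0.26 log units; within the scatter). Compound 3 is estimated at 30 nM in this assay, within 8 nM to 120 nM.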

Compound 3, inhibition constant: 223 nM
Estimate against measurement, compound 3: 7.4-fold (0.87 log units) below; the whole stated range lies below it.
By their numbers in this assay, from the lowest: compound 2; then compound 1; then compound 3.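

In this assay, among these compounds, amino to benzamido gives a 4.1-fold higher number from compound 1 to compound 3 (0.62 log units; beyond the scatter) as the only measured step, and it shows that this nitrogen on an aromatic ring is not indifferent to substitution. Benzoyl in place of hydrogen moves the number upward here, and the change stays within a measurable range. No available evidence bears on what lies behind this step. As far as these compounds go, whether acetyl or methyl on the same nitrogen moves the number in the same direction remains open. So does whether benzoyl has the same effect on the core of compound 2.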